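The source may report more compounds than this note shows. Statements on the series, on what has been measured and on what is new or still open speak of the compounds shown alone.

In an assay on isolated protein for inhibition of histamine H2 receptor (Cavia porcellus) (on this read-out higher numbers stand for weaker binding and lower numbers for tighter binding), compound 3 `CCCCNC(=O)NCCCOc1cccc(CN2CCCCC2)c1` gives 81.3 nM, the lowest number among the three measured compounds; compound 2 `CC(C)CNC(=O)NCCCOc1cccc(CN2CCCCC2)c1` gives 170 nM and compound 1 `O=C(NCCCOc1cccc(CN2CCCCC2)c1)NCc1ccccc1` gives 347 nM. The recorded steps are a 2.0-fold lower number from compound 1 to compound 2 (0.31 log units; beyond the scatter), a 4.3-fold lower number from compound 1 to compound 3 (0.63 log units; beyond the scatter) and a 2.1-fold lower number from compound 2 to compound 3 (0.32 log units; beyond the scatter), each beyond the scatter. Compound 4 `O=C(NCCCOc1cccc(CN2CCCCC2)c1)Nc1cccc(Cl)c1` differs from compound 3 by 3-chlorophenyl in place of butyl on an amide-type nitrogen. Among the measured compounds shown here, the nearest precedent is the change between compound 1 and compound 3, where a phenyl-bearing chain at that nitrogen gave the highest number of the three; a ring bound directly to the nitrogen has no measured precedent here. The expected outcome is a move back towards the number of compound 1, a 3.1-fold higher number from compound 3 to compound 4 (0.49 log units; beyond the scatter). For compound 4 the estimate is 250 nM, with a range from 80 nM to 800 nM.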

Compound 4, dissociation constant: 316 nM
Estimate against measurement, compound 4: 1.3-fold (0.10 log units) below; the range from low to high includes it.
By their numbers in this assay, from the lowest: compound 3; then compounds 2, 4 and 1 (each within the scatter of the next, the first and the last beyond it).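

At the amide-type nitrogen, 3-chlorophenyl gives up the advantage of butyl in this assay (a 3.9-fold higher number from compound 3 to compound 4 (0.59 log units; beyond the scatter)). It stays within the scatter of isobutyl (a 1.9-fold higher number from compound 2 to compound 4 (0.27 log units; within the scatter)) and of benzyl (a 1.1-fold lower number from compound 1 to compound 4 (0.04 log units; within the scatter)), so a ring bound directly to this nitrogen matches the benzyl result of compound 1 in this series. No evidence here accounts for these steps. Compound 4 differs from compound 1 in both the chlorine and the benzyl carbon, so their separate contributions remain unresolved. Plain phenyl, and chains longer than butyl, remain open.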